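This account rests on a few compounds, and the source may have more. Where it says the series, first, only, none or still open, it means among the compounds named here.

Measured so far in an ADME assay on MT4 cells (Homo sapiens) for cytotoxicity, read by MTT assay, with a stated time of 5 days; a lower number here means that less compound is tolerated, a higher number that more compound is tolerated:
- compound 2 `Cc1cc(/C=C/C#N)cc(C)c1Oc1cc(Nc2ccc(C#N)cc2)nc(NC2CC2)c1` gives 24800 nM
- compound 1 `C=CCNc1cc(Oc2c(C)cc(/C=C/C#N)cc2C)nc(Nc2ccc(C#N)cc2)n1` gives 3050 nM
- compound 3 `COC(Nc1cc(Oc2c(C)cc(/C=C/C#N)cc2C)nc(Nc2ccc(C#N)cc2)n1)OC` gives 3470 nM

Compound 2 holds the highest of the three numbers in this assay, and its gap to compound 3 and to compound 1 lies beyond the scatter in each case. Compound 4 `Cc1cc(/C=C/C#N)cc(C)c1Oc1cc(NCCN2CCN(C)CC2)nc(Nc2ccc(C#N)cc2)c1` is the next to be measured. The change from compound 2 is 2-(4-methylpiperazin-1-yl)ethyl in place of cyclopropyl on a nitrogen on an aromatic ring. Within the data shown here, the only measured step, a 1.1-fold higher number from compound 1 to compound 3 (0.06 log units; within the scatter), is within the scatter, sits on the core of compound 1 rather than that of compound 2, and exchanges a different pair of groups, so it bears on this step only loosely. Among the measured compounds shown here, no measured step exchanges cyclopropyl for 2-(4-methylpiperazin-1-yl)ethyl. Compound 4 is therefore expected near compound 2, with an estimated step of a 1.2-fold lower number from compound 2 to compound 4 (0.09 log units; within the scatter) and an estimate of 20000 nM (range 7000 nM to 60000 nM).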

Compound 4, half-maximal cytotoxic concentration: 7960 nM
Estimate against measurement, compound 4: 2.5-fold (0.40 log units) above; low and high end bracket the measured number.
By their numbers in this assay, from the lowest: compounds 1 and 3 (each within the scatter of the next); then compound 4; then compound 2.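

Exchanging cyclopropyl for 2-(4-methylpiperazin-1-yl)ethyl on a nitrogen on an aromatic ring gives a 3.1-fold lower number from compound 2 to compound 4 (0.49 log units; beyond the scatter) in this assay. This position therefore responds to the group it carries, a response the step between compounds on the core of compound 1 did not show. No measurement at hand gives a cause for this step.

On these data alone, whether the chain or the ring of the entering group drives the step stays open; a 2-(dimethylamino)ethyl group on that nitrogen would bear on this. As far as these compounds go, whether the exchange behaves alike on the core of compound 1 also stays open.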